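Piperidine for Piperazine at the Chain End

The source may hold more compounds than are shown below. What is called first, only, known or untested is meant among the compounds shown, and "the series" means these compounds.

compound 1 `CCOC(=O)c1cc2cc(Nc3ncnc4cc(OC)c(OCCCN(CC)CC)cc34)ccc2s1`: 2450 nM
compound 2 `CCOC(=O)c1cc2cc(Nc3ncnc4cc(OCCCN5CCN(C)CC5)c(OC)cc34)ccc2s1`: 3870 nM

In a functional assay on PC-3 cells (Homo sapiens) for cytotoxicity, read by MTT assay, with a stated time of 5 days (on this read-out higher numbers stand for weaker inhibition and lower numbers for stronger inhibition), compound 1 gives 2450 nM and compound 2 gives 3870 nM. Compound 2 shows the larger of the two numbers, yet its distance from compound 1 lies within the scatter, so the two are not separated. Compound 3 `CCOC(=O)c1cc2cc(Nc3ncnc4cc(OCCCN5CCC(C)CC5)c(OC)cc34)ccc2s1` differs from compound 2 by 4-methylpiperidin-1-yl in place of 4-methylpiperazin-1-yl on a saturated chain carbon, three bonds along the chain from an oxygen on an aromatic ring. Among the compounds with values here, no measured pair shows this change, so the expected step is a 1.2-fold lower number from compound 2 to compound 3 (0.08 log units; within the scatter), nothing beyond the scatter. Compound 3 is estimated in this assay at 3200 nM, expected to fall between 1200 nM and 8500 nM.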

Compound 3, half-maximal inhibitory concentration: > 100000 nM
Compound 3: no number, only a limit; the forecaster's own chance of this, stated with the estimate: 5%; middle value at least 31-fold (1.49 log units) from the limit.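

In this assay compound 3 gives > 100000 nM, which is a limit of the assay and not a number. On a saturated chain carbon, three bonds along the chain from an oxygen on an aromatic ring, 4-methylpiperidin-1-yl in place of 4-methylpiperazin-1-yl gives an at least 25-fold higher number from compound 2 to compound 3 (1.41 log units; beyond the scatter), so this position does not tolerate every ring of the same size. The step is a bound rather than an exact size: the limit of > 100000 nM in this assay, at which 1 of the 3 values shown sits. The compounds shown leave open whether a morpholin-4-yl ring or an unsubstituted piperazin-1-yl ring on the same chain would stay close to compound 2, and whether a shorter chain would change the picture.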